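A Methyl Added to the Side Chain of Compound 2

The source may hold more compounds than are shown below. What is called first, only, known or untested is meant among the compounds shown, and "the series" means these compounds.

Among the measured compounds shown here, in a functional assay on A2780 cells (Homo sapiens) for inhibition, read by sulforhodamine B assay, with a stated time of 96 h (on this read-out higher numbers stand for weaker inhibition of growth and lower numbers for stronger inhibition of growth), compound 2 `CC[C@@H](Nc1nc(NCc2ccccn2)c2ncn(C(C)C)c2n1)C(C)O` gives 27000 nM, the only actual number so far. Compound 1 `CC[C@@H](Nc1nc(NCc2ccccn2)c2ncn(C(C)C)c2n1)C(C)(C)O` gives > 50000 nM, which is a limit of the assay and not a number. Compound 3 `CCC(O)[C@@H](CC)Nc1nc(NCc2ccccn2)c2ncn(C(C)C)c2n1` departs from compound 2 by one change: methyl in place of hydrogen on a saturated chain carbon, two bonds along the chain from an oxygen on a saturated carbon. It carries methyl in place of hydrogen on a saturated chain carbon, two bonds along the chain from an oxygen on a saturated carbon, so methyl becomes ethyl. For the measured compounds named here, the only measured step that bears on this is an at least 1.8-fold lower number from compound 1 to compound 2 (0.26 log units; that floor lies within the scatter), which concerns a methyl on a different carbon, one bound to the oxygen. Since that step does not clear the scatter, no step beyond the scatter is expected in this assay. The expected step is a 1.2-fold higher number from compound 2 to compound 3 (0.09 log units; within the scatter). For compound 3 the estimated value is 33000 nM, with an expected range of 14000 nM to 50000 nM.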

Compound 3, concentration for 50% growth inhibition: 40000 nM
Beside the measured number, compound 3's estimate is 1.2-fold (0.08 log units) below it, and the stated range covers the measured number.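

Methyl to ethyl at this position, two bonds along the chain from an oxygen on a saturated carbon, gives in this assay a 1.5-fold higher number from compound 2 to compound 3 (0.17 log units; within the scatter). Among the compounds shown here, this is the first step in the set read between two actual numbers rather than against a limit, and it shows that this added methyl makes no difference that can be told from the scatter. The other new step, an at least 1.2-fold lower number from compound 1 to compound 3 (0.09 log units; that floor lies within the scatter), starts from a limit of the assay and gives only a floor: the limit of > 50000 nM in this assay, at which 1 of the 3 values shown sits.

No step shown clears the scatter, so what this position can do to growth inhibition remains open. From the compounds shown here alone, whether a longer chain such as 1-hydroxybutyl, or an amine or a carboxylic acid in place of the hydroxyl group, would move the number beyond the scatter also stays open.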